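A few compounds are considered here, and "the series" means these few. Any claim that something is new, unique, unknown or untested is made for them only; others in the source may bear on it.

Working notes on the series: in a functional assay on A-375 cells (Homo sapiens) for inhibition, read by MTT assay, with a stated time of 5 days (a lower number here means a stronger inhibitor, a higher number a weaker inhibitor), compound 1 `Nc1nccc(-c2sc(C3CCN3)nc2-c2cccc(NS(=O)(=O)c3cc(F)ccc3F)c2F)n1` gives 32.8 nM, compound 2 `Nc1nccc(-c2sc(C3CCCN3)nc2-c2cccc(NS(=O)(=O)c3cc(F)ccc3F)c2F)n1` gives 11.2 nM, and compound 3 `Nc1nccc(-c2sc(C3CCN(C4CC4)CC3)nc2-c2cccc(NS(=O)(=O)c3cc(F)ccc3F)c2F)n1` gives 1.68 nM, leaving compound 2 as the middle of the three numbers. Compound 4 `NCCCc1nc(-c2cccc(NS(=O)(=O)c3cc(F)ccc3F)c2F)c(-c2ccnc(N)n2)s1` is the next case: 3-aminopropyl in place of pyrrolidin-2-yl on an aromatic carbon. In words, 3-aminopropyl stands in place of pyrrolidin-2-yl on an aromatic carbon. Three measured steps change the same place: a 2.9-fold lower number from compound 1 to compound 2 (0.47 log units; beyond the scatter) and a 6.7-fold lower number from compound 2 to compound 3 (0.82 log units; beyond the scatter) are modest, and a 20-fold lower number from compound 1 to compound 3 (1.29 log units; beyond the scatter) is large. On these data alone, all three lead from one ring-bearing group to another, so none shows the effect of an entering group with no ring, and the direction stays open. The expected change is a 1.3-fold higher number from compound 2 to compound 4 (0.10 log units; within the scatter), with no step beyond the scatter expected. Compound 4 is estimated at 14 nM, with an expected range of 4 nM to 50 nM.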

Compound 4, half-maximal inhibitory concentration: 39.5 nM
The estimate for compound 4 lay 2.8-fold (0.45 log units) below the measured number, and the stated range covers the measured number.
By their numbers in this assay, from the lowest: compound 3; then compound 2; then compounds 1 and 4 (each within the scatter of the next).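

In this assay, for the compounds shown here, the first group with no ring at this position, 3-aminopropyl, separates from two of the ring-bearing groups: a 3.5-fold higher number from compound 2 to compound 4 (0.55 log units; beyond the scatter) and a 24-fold higher number from compound 3 to compound 4 (1.37 log units; beyond the scatter) both lie beyond the scatter. Ring-bearing groups are therefore not uniformly better, since a 1.2-fold higher number from compound 1 to compound 4 (0.08 log units; within the scatter) stays within the scatter and leaves 3-aminopropyl and azetidin-2-yl unseparated. No evidence on why these steps arise is at hand.

Still open, on these data alone, is whether a longer chain ending in an amine, or a chain ending in a carboxylic acid, would stand nearer compound 4 or compound 2.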